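The source may hold more compounds than are shown below. What is called first, only, known or untested is meant among the compounds shown, and "the series" means these compounds.

Measured compounds in this series:
- compound 1 `Cc1ccc(-n2nc(C(C)(C)C)cc2NC(=O)Nc2cc(F)cc(F)c2)cc1` — 2.8 degrees C
- compound 2 `CC(C)(C)c1cc(NC(=O)Nc2ccc(Cl)cc2)n(-c2ccc(OC(F)(F)F)cc2)n1` — 0.2 degrees C
- compound 3 `O=C(Nc1ccc(Cl)cc1)Nc1cc(C2CC2)nn1-c1ccc(OC(F)(F)F)cc1` — 0.3 degrees C

In an assay on isolated protein for inhibition of STE20-like serine/threonine-protein kinase (Homo sapiens), read by thermal shift assay, tested at 10 uM (on this read-out higher numbers stand for stronger stabilisation of the target against heat and lower numbers for weaker stabilisation of the target), compound 2 stands lowest of the three numbers. Its nearest neighbour is compound 3, with a number 0.10 degrees C higher from compound 2 to compound 3 (within the scatter), a step within the scatter. For the measured compounds named here, compound 1 gives 2.8 degrees C, which lies beyond the scatter above compound 2, but compound 1 and compound 2 differ in two places, so no single step is defined between them.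

Compound 4 `CC(C)C(=O)Nc1ccc(-n2nc(C(C)(C)C)cc2NC(=O)Nc2ccc(Cl)cc2)cc1` differs from compound 2 by (isopropylcarbonyl)amino in place of trifluoromethoxy on an aromatic carbon. Going by the values given here, no measured step touches this position; the only measured step, from compound 2 to compound 3, concerns the tert-butyl and was within the scatter, so it does not bear on the change. Among the compounds with values here, with no relevant step, the estimate for compound 4 in this assay starts from the low value of compound 2 and allows a wide range upward: compound 4 is expected at 1 degrees C, between -0.5 degrees C and 3 degrees C, an expected step of a number 0.80 degrees C higher from compound 2 to compound 4 (within the scatter).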

Compound 4, shift of the target's melting temperature: 6.8 degrees C
The estimate for compound 4 lay 5.8 degrees C below the measured number; the measured number lies above the stated range.
By their numbers in this assay, from the lowest: compounds 2 and 3 (each within the scatter of the next); then compound 1; then compound 4.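

For the compounds shown here, on the aromatic carbon para to a large group, (isopropylcarbonyl)amino in place of trifluoromethoxy gives, in this assay, a number 6.6 degrees C higher from compound 2 to compound 4 (beyond the scatter), the first single-place step beyond the scatter. The change brings in a hydrogen-bond donor and a double bond outside aromatic rings, but this one pair cannot separate their contributions. No measured evidence accounts for the step.

From the compounds shown here alone, whether the step depends on the amide hydrogen or on the isopropyl part remains open; a simple amine, an acetamide or a longer acyl chain here would help separate them. Also open, going by these compounds, is whether the step persists with cyclopropyl in place of tert-butyl.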